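Swapping cyano for methylsulfonyl on compound 2

The source may report more compounds than this note shows. Statements on the series, on what has been measured and on what is new or still open speak of the compounds shown alone.

Compound 1 `CS(=O)(=O)c1ccc(-c2cnc(N)c(-c3ccc(C(F)(F)F)cc3)c2)cc1`: < 7 mL.min-1.g-1 (a limit)
Compound 2 `CS(=O)(=O)c1ccc(-c2cnc(N)c(-c3ccc(C#N)cc3)c2)cc1`: < 5 mL.min-1.g-1 (a limit)

Both compounds were tested in an in vitro ADME assay on microsomes from liver (Homo sapiens) for metabolic stability, with a stated time of 60 min, tested at 1 uM (a higher number here means faster removal of the compound, a lower number slower removal), and neither returned a number. Compound 2 gives < 5 mL.min-1.g-1, which is a limit and so marks where it stands only on one side. Compound 1 gives < 7 mL.min-1.g-1, which is also a limit.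

Compound 3 `CS(=O)(=O)c1ccc(-c2cnc(N)c(-c3ccc(S(C)(=O)=O)cc3)c2)cc1` keeps the shared core and carries methylsulfonyl in place of cyano on an aromatic carbon. Going by the values given here, only one measured step bears on this change, a step that the two limits leave unreadable from compound 1 to compound 2, and it concerns the same place on the core. It offers no size to carry over, so it gives no reason to expect a large move in either direction in this assay. The expectation rests on compound 2 with < 5 mL.min-1.g-1 as a limit, and nothing measured points to faster removal. No change beyond the scatter is expected, and the expected step is a step that the limit leaves unreadable from compound 2 to compound 3 here. The estimate for compound 3 is 4 mL.min-1.g-1, with an expected range from 2 mL.min-1.g-1 to 8 mL.min-1.g-1, and a report as a limit alone is likely.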

Compound 3, intrinsic clearance in microsomes: < 5 mL.min-1.g-1
Compound 3 gave a limit, no number; the forecaster's own chance of this, stated with the estimate: 85%; the middle value does not contradict the limit.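

In this assay, going by these compounds alone, compound 3 gives < 5 mL.min-1.g-1, which is a limit, so no step among compound 1, compound 2 and compound 3 can be read. The compounds shown leave open whether trifluoromethyl, cyano and methylsulfonyl on this aromatic carbon differ at all in intrinsic clearance in microsomes.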